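The source may report more compounds than this note shows. Statements on the series, on what has been measured and on what is new or still open speak of the compounds shown alone.

Measured compounds:
Compound 1 `O=C(N/N=C/c1cc(I)cc(I)c1O)c1ccccc1`: in a functional assay on HepG2 cells (Homo sapiens) for cytotoxicity, with a stated time of 24 h (on this read-out lower numbers stand for stronger inhibition and higher numbers for weaker inhibition), compound 1 gives > 50000 nM, which is a limit of the assay, not a number.
Compound 2 `O=C(N/N=C/c1cc(I)cc(I)c1O)c1ccc(Cl)cc1`: compound 2 gives 14800 nM.

Compound 2 thus carries the only number shown in this assay; the other value is the limit (the limit of > 50000 nM in this assay, at which 1 of the 2 values shown sits). Going by the values given here, the one measured step, an at least 3.3-fold lower number from compound 1 to compound 2 (0.52 log units; beyond the scatter), is the only evidence bearing on the next change. Compound 3 `O=C(N/N=C/c1cc(I)cc(I)c1O)c1ccc(C(F)(F)F)cc1` differs from compound 2 by trifluoromethyl in place of chloro on an aromatic carbon. That earlier step shows a group at this spot matters, but says nothing about swapping one group for another, so for compound 3 I expect a change within the scatter, a 1.2-fold lower number from compound 2 to compound 3 (0.09 log units; within the scatter). My estimate for compound 3 is 12000 nM, between 4000 nM and 40000 nM.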

Compound 3, half-maximal inhibitory concentration: 11700 nM
Beside the measured number, compound 3's estimate is 1.0-fold (0.01 log units) above it, and the stated range covers the measured number.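

In this assay the change from chloro to trifluoromethyl gives a 1.3-fold lower number from compound 2 to compound 3 (0.10 log units; within the scatter) so these two groups cannot be told apart at this position. Trifluoromethyl in place of hydrogen gives an at least 4.2-fold lower number from compound 1 to compound 3 (0.63 log units; beyond the scatter) so the drop seen with chloro is not unique to chloro. On these data alone, the true size of that step is unknown, since compound 1 stands at a limit of the assay and not at a number: the limit of > 50000 nM in this assay, at which 1 of the 3 values shown sits.

As far as these compounds go, whether an amine, a carboxylic acid or a longer chain at this position would give a similar number stays open, as does the effect of any change elsewhere on the shared core.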